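Swapping chloro for methoxy on the indole-linked ring

The source may report more compounds than this note shows. Statements on the series, on what has been measured and on what is new or still open speak of the compounds shown alone.

Measured so far in an assay on isolated protein for inhibition of Aromatase (Homo sapiens), read by ELISA, using NADPH, with a stated time of 24 h; a lower number here means a stronger inhibitor, a higher number a weaker inhibitor:
compound 1, `Clc1ccc(-c2[nH]c3cc(Cl)ccc3c2Cn2ccnc2)cc1`, gives 261 nM
compound 2, `COc1ccc(-c2[nH]c3cc(Cl)ccc3c2Cn2ccnc2)cc1`, gives 277 nM
compound 3, `Fc1ccc2c(Cn3cncn3)c(-c3ccc(Cl)cc3)[nH]c2c1`, gives 217 nM

Compound 1 and compound 2 differ by one change, (methoxy in place of chloro on an aromatic carbon), and the step was a 1.1-fold higher number from compound 1 to compound 2 (0.03 log units; within the scatter). Compound 3 carries a different core; the difference between the two cores is not broken down here, but its value lies within the scatter of both compound 1 and compound 2. Compound 4, `COc1ccc(-c2[nH]c3cc(F)ccc3c2Cn2cncn2)cc1`, has not yet been measured in this assay. It differs from compound 3 by the same change, (methoxy in place of chloro on an aromatic carbon), made at the same place. Because the earlier step was a 1.1-fold higher number from compound 1 to compound 2 (0.03 log units; within the scatter), the expected step here is a 1.1-fold higher number from compound 3 to compound 4 (0.03 log units; within the scatter). Compound 4 is therefore estimated at 230 nM, between 110 nM and 480 nM.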

Compound 4, half-maximal inhibitory concentration: 14.1 nM
For compound 4 the middle estimate is 16-fold (1.21 log units) above the measured one; measured number outside the range, below it.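

In this assay, putting methoxy in place of chloro gives a 15-fold lower number from compound 3 to compound 4 (1.19 log units; beyond the scatter), a large step on the core of compound 3. The same change does not carry over with the same size from one core to the other: the same change on two cores in this assay, a 1.1-fold higher number (0.03 log units; within the scatter) from compound 1 to compound 2 and a 15-fold lower number (1.19 log units; beyond the scatter) from compound 3 to compound 4, 16-fold (1.21 log units) apart, beyond the scatter of two such steps. Within the data shown here, this shows that, in these two pairs, the size of the step differs with the core, but with only one pair on each core it does not show which difference between the cores matters, or why.

The compounds shown leave open how an ethoxy group or an amine in the same place would behave on either core. They also leave open whether a third core would follow compound 2 or compound 4.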